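The compounds below may be only part of what the source reports. "The series", "measured", "known", "first", "only" and "open" are said of these compounds alone.

Compound 2 `CC(/C=N/Nc1ccc([N+](=O)[O-])cc1)=N\NC(=O)c1ccccc1N` is measured in an ADME assay on J774 cells (Mus musculus, strain BALB/c) for cytotoxicity, read by resazurin assay, with a stated time of 72 h (a lower number here means that less compound is tolerated, a higher number that more compound is tolerated), at 29800 nM, the lowest of the three numbers in hand. Compound 1 `CC(/C=N/N(C)c1ccc([N+](=O)[O-])cc1)=N\NC(=O)c1ccc(N)cc1` gives 51700 nM in this assay, within the scatter of compound 2, while compound 3 `CC(/C=N/Nc1ccc([N+](=O)[O-])cc1)=N\NC(=O)c1ccc(Cl)cc1` gives 63900 nM. Among the compounds with values here, the one step that can be read across this set runs between the last two: a 2.1-fold higher number from compound 2 to compound 3 (0.33 log units; beyond the scatter), a modest rise in the tolerated concentration when 4-chlorophenyl replaces 2-aminophenyl on the carbonyl carbon. Compound 4 `CC(/C=N/Nc1ccc([N+](=O)[O-])cc1)=N\NC(=O)c1ccccc1C` has not yet been tested. It differs from compound 2 by methyl in place of amino on an aromatic carbon, so that, as in compound 3, the amino on the six-membered aromatic ring at the carbonyl carbon is gone, here in favour of a methyl. Within the data shown here, only the step from compound 2 to compound 3 bears on this change, and it was modest. A step of about the same kind is therefore expected for compound 4, a rise in this assay that may or may not clear the scatter, namely a 1.5-fold higher number from compound 2 to compound 4 (0.18 log units; within the scatter). Compound 4 is accordingly expected to give about 45000 nM in this assay, with a range from 25000 nM to 80000 nM.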

Compound 4, half-maximal cytotoxic concentration: > 100000 nM
Compound 4 ended at the assay's limit; the forecaster's own chance of this, stated with the estimate: 5%; middle value at least 2.2-fold (0.34 log units) from the limit.
By their numbers in this assay, from the lowest: compounds 2, 1 and 3 (each within the scatter of the next, the first and the last beyond it). At a limit, above all of these: compound 4.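

In this assay compound 4 gives > 100000 nM, which is a limit of the assay and not a number: the limit of > 100000 nM in this assay, at which 1 of the 4 values shown sits. Methyl in place of amino on this aromatic carbon, ortho to a large group, brings an at least 3.3-fold higher number from compound 2 to compound 4 (0.52 log units; beyond the scatter), so this single-atom change moves the number beyond the scatter, and how far beyond remains unknown. The change from 4-chlorophenyl to 2-methylphenyl gives an at least 1.5-fold higher number from compound 3 to compound 4 (0.19 log units; that floor lies within the scatter), so that floor alone does not separate the two compounds.

The compounds shown do not tell whether the rise follows the loss of amino or the arrival of methyl. They also leave open how a hydroxyl, a methoxy or a longer chain would read on this aromatic carbon.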